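The source may report more compounds than this note shows. Statements on the series, on what has been measured and on what is new or still open speak of the compounds shown alone.

Compound 1: `COc1cc(Cl)cc(-c2nn(-c3cccc(NC(=O)Nc4ccc(Cl)c(Cl)c4)c3)cc2-c2ccncc2)c1`; in a functional assay on T47D cells (Homo sapiens) for inhibition, read by sulforhodamine B assay, with a stated time of 48 h, tested at 0.1 uM (on this read-out lower numbers stand for a stronger effect and higher numbers for a weaker effect at the one concentration tested), compound 1 gives 94%.
Compound 2: `COc1cc(Cl)cc(-c2nn(-c3cccc(NC(=O)Nc4cccc(C(F)(F)F)c4)c3)cc2-c2ccncc2)c1`; in this assay compound 2 gives 94%.

For the measured compounds named here, compound 2 stands level with compound 1 at the digits printed: the one measured step, no change at the digits printed from compound 1 to compound 2 (within the scatter), stayed within the scatter, so exchanging one substituted phenyl for another on the amide-type nitrogen left the read-out where it was. Both compounds thus show only a small effect at the single concentration tested.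

Compound 3, `COc1cc(Cl)cc(-c2nn(-c3cccc(NC(=O)c4cccc(C(F)(F)F)c4)c3)cc2-c2ccncc2)c1`, has not yet been measured. It differs from compound 2 in this way: 3-(trifluoromethyl)phenyl in place of (3-(trifluoromethyl)phenyl)amino on a carbonyl carbon. The urea linkage of compound 2 becomes an amide, and one hydrogen-bond donor is lost.

Going by the values given here, no measured step touches this kind of change; the only step available, from compound 1 to compound 2, alters the outer aryl group and not the linker, and it was flat. With nothing pointing in either direction, the expectation is a step of about a number 2 percentage points lower from compound 2 to compound 3 (within the scatter), that is, no change beyond the scatter. Compound 3 is therefore estimated at 92%, within the range 78% to 102%.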

Compound 3, a percentage reported as activity, at one concentration (the size of the read-out at that concentration, not a potency): 101%
Estimate against measurement, compound 3: 9 percentage points below; the measured number falls inside the stated range.
By their numbers in this assay, from the lowest: compounds 1, 2 and 3 (each within the scatter of the next).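

In this assay, the urea linkage gives way to an amide: the (3-(trifluoromethyl)phenyl)amino group on the carbonyl carbon, which carries a hydrogen-bond donor, is replaced by 3-(trifluoromethyl)phenyl, which carries none, and the result is a number 7 percentage points higher from compound 2 to compound 3 (within the scatter) at the one concentration tested. For the compounds shown here, this is the first look at the linker rather than the outer aryl group, and it shows that, in this pair, the amino nitrogen and its hydrogen can go without the read-out moving beyond the usual variation between repeats; the comparison with the dichlorinated urea agrees, with a number 7 percentage points higher from compound 1 to compound 3 (within the scatter) even though the outer ring differs as well. Nothing available explains this flat result.

On these data alone, whether a sulfonamide in place of the amide, or a longer chain between the carbonyl carbon and the outer ring, would shift the read-out beyond that variation remains open. As far as these compounds go, with all three compounds read at a single concentration and lying within the scatter of one another, whether any of them has a stronger or weaker effect at that concentration also stays open, so a real difference between urea and amide at other concentrations cannot be ruled out.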